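The source may report more compounds than this note shows. Statements on the series, on what has been measured and on what is new or still open speak of the compounds shown alone.

Compound 1 `COc1cc(C2=C(c3cc(C)c(OC)c(C)c3)C(O)CC2=O)cc(OC)c1OC`: > 100 ug/mL
Compound 2 `COc1cc(C2=C(c3cc(C)c(OC)c(C)c3)C(OC(C)=O)CC2=O)cc(OC)c1OC`: > 100 ug/mL
Compound 3 `COC(=O)c1cc(C2=C(c3cc(OC)c(OC)c(OC)c3)C(=O)CC2O[SiH2]C(C)(C)C)ccc1OC`: > 100 ug/mL

All three entries are limits in an ADME assay on MIA PaCa-2 cells (Homo sapiens) for cytotoxicity, read by MTT assay, with a stated time of 72 h (on this read-out lower numbers stand for stronger inhibition and higher numbers for weaker inhibition), not numbers. Compound 2 therefore has no numerical position in the series and sits with the others at the limit of > 100 ug/mL in this assay, at which 3 of the 3 values shown sit.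

Compound 4 `COc1ccc(C2=C(c3cc(OC)c(OC)c(OC)c3)C(=O)CC2OC(C)=O)cc1NC=O` differs from compound 2 as follows: 3-(formylamino)-4-methoxyphenyl in place of 4-methoxy-3,5-dimethylphenyl on a double-bonded ring carbon. Among the measured compounds shown here, the only measured step, a step that the two limits leave unreadable from compound 1 to compound 2, is acetyl in place of hydrogen on an oxygen on a saturated carbon. It is a different change and gives no usable size. Any shift in this assay can be read only toward stronger inhibition, and a wide margin is needed. The expected change is an at least 1.2-fold lower number from compound 2 to compound 4 (0.09 log units; that floor lies within the scatter). For compound 4 the estimate is 80 ug/mL, with an expected range of 10 ug/mL to 150 ug/mL.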

Compound 4, half-maximal inhibitory concentration: 2 ug/mL
For compound 4 the middle estimate is 40-fold (1.60 log units) above the measured one; the whole stated range lies above it.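

In this assay, among the compounds shown here, the group on the double-bonded ring carbon is the first place where a change can be read: 3-(formylamino)-4-methoxyphenyl in place of 4-methoxy-3,5-dimethylphenyl gives an at least 50-fold lower number from compound 2 to compound 4 (1.69 log units; beyond the scatter) at this position. Compound 2 gives > 100 ug/mL as a limit. Compound 4 is the only compound shown that leaves this limit: the limit of > 100 ug/mL in this assay, at which 3 of the 4 values shown sit.

As far as these compounds go, whether the step belongs to the formylamino group or to the loss of the methyl groups stays open. Also open, from the compounds shown here alone, is how this assay would read a free amine or an acetylamino group in that place.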